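The compounds below may be only part of what the source reports. "The series", "measured", "known", "first", "only" and "open" are said of these compounds alone.

In a functional assay on NCI-H460 cells (Homo sapiens) for inhibition, read by sulforhodamine B assay, with a stated time of 48 h (on this read-out lower numbers stand for stronger inhibition of growth and higher numbers for weaker inhibition of growth), compound 1 (`N#CCC1=NN=C(c2ccc([N+](=O)[O-])cc2)CO1`) gives 2 nM and stands far from compound 2 (`N#CCC1=NN=C(c2ccc(Br)cc2)C(Br)O1`), which gives 38200 nM as the higher of the two numbers, a gap well beyond the usual scatter. Compound 3 (`N#CCC1=NN=C(c2ccc(Br)cc2)CO1`) has no number yet. It differs from compound 2 in one place, with hydrogen in place of bromo on a saturated ring carbon. Among the compounds with values here, no step between measured compounds differing in one place is available, so the expectation rests on thin evidence. Since compound 2 sits at 38200 nM at the top of the two numbers, a lower number is expected from this change, though the margin is uncertain. The expected move is a 13-fold lower number from compound 2 to compound 3 (1.10 log units; beyond the scatter) (an estimate, beyond the scatter). Compound 3 is thus estimated at 3000 nM (expected range 150 nM to 30000 nM).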

Compound 3, concentration for 50% growth inhibition: 900 nM
Estimate against measurement, compound 3: 3.3-fold (0.52 log units) above; the measured number falls inside the stated range.
By their numbers in this assay, from the lowest: compound 1; then compound 3; then compound 2.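

In this assay the bromo on the saturated ring carbon, next to the ring oxygen, turns out to weigh heavily on growth inhibition: hydrogen in its place gives a 42-fold lower number from compound 2 to compound 3 (1.63 log units; beyond the scatter) and so a much stronger compound. With hydrogen on that carbon in both compounds, the aromatic position can now be read on its own, and bromo in place of nitro gives a 450-fold higher number from compound 1 to compound 3 (2.65 log units; beyond the scatter), so the wide gap between the two earlier compounds is spread over two places, each with a step beyond the scatter. No measurement at hand accounts for either step.

From the compounds shown here alone, whether nitro on the aromatic carbon would keep its advantage with bromo on the saturated ring carbon remains open. So does the effect of an amine or a carboxylic acid on the aromatic carbon, or of a methyl group on the saturated ring carbon.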